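Swapping benzyl for 3-bromophenyl on an inactive compound

The source may hold more compounds than are shown below. What is called first, only, known or untested is meant among the compounds shown, and "the series" means these compounds.

In a functional assay on MDA-MB-231 cells (Homo sapiens) for antiproliferative activity, read by MTT assay, with a stated time of 72 h (a lower number here means a stronger inhibitor, a higher number a weaker inhibitor), compound 1 `O=C(CCc1cccc2c1B(O)OC2)NCc1ccccc1` gives > 100000 nM, which is a limit of the assay and not a number. In this assay compound 2 `CC(C)(C)OC(=O)Nc1ccc(NC(=O)CCc2cccc3c2B(O)OC3)cc1` gives 29000 nM, and compound 3 `CC(C)(C)OC(=O)NCc1ccc(NC(=O)CCc2cccc3c2B(O)OC3)cc1` gives 1300 nM. Compound 4 `O=C(CCc1cccc2c1B(O)OC2)Nc1cccc(Br)c1` carries 3-bromophenyl in place of benzyl on an amide-type nitrogen. Going by the values given here, the only measured step, a 22-fold lower number from compound 2 to compound 3 (1.35 log units; beyond the scatter), is large, but it changes a different group, so it bears on this swap only indirectly. Compound 2, at 29000 nM, is the cautious guide, so a move to a lower number is expected, of modest size. The estimated step is an at least 2.8-fold lower number from compound 1 to compound 4 (0.45 log units; beyond the scatter). For compound 4 the expected value is 35000 nM, with an estimated range of 10000 nM to 100000 nM.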

Compound 4, half-maximal inhibitory concentration: 720 nM
For compound 4 the middle estimate is 49-fold (1.69 log units) above the measured one, and the stated range ends above it.
By their numbers in this assay, from the lowest: compounds 4 and 3 (each within the scatter of the next); then compound 2. At a limit, above all of these: compound 1.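

The group on the amide-type nitrogen matters a great deal here: swapping benzyl for 3-bromophenyl gives an at least 130-fold lower number from compound 1 to compound 4 (2.14 log units; beyond the scatter) in this assay, whereas the earlier step concerned a different group. Compound 1 stands at a limit of the assay and not at a number, so this step has only a minimum size: the limit of > 100000 nM in this assay, at which 1 of the 4 values shown sits.

The swap removes the carbon linking the ring to the nitrogen and adds a bromine together, and the compounds shown do not separate the two. A plain phenyl on this nitrogen would show how much the bromine itself contributes.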